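Methyl Where Methoxy Once Stood: Expecting Compound 4

The source may hold more compounds than are shown below. What is called first, only, known or untested is meant among the compounds shown, and "the series" means these compounds.

Compound 1, `COc1ccc2[nH]c(=O)c(-c3nc4cc(F)ccc4[nH]3)cc2c1`, gives in a functional assay on BEL-7404 cells for cytotoxicity against BEL-7404 tumor cell line (Homo sapiens), read by MTT assay, with a stated time of 48 h (on this read-out lower numbers stand for stronger inhibition and higher numbers for weaker inhibition), a limit of the assay, > 100000 nM.
Compound 2, `O=c1[nH]c2ccccc2cc1-c1nc2cc(F)ccc2[nH]1`, gives in this assay 27500 nM.
Compound 3, `O=c1[nH]c2ccccc2cc1-c1nc2cc([N+](=O)[O-])ccc2[nH]1`, gives in this assay a limit of the assay, > 100000 nM.

Going by the values given here, compound 2 therefore holds the only numerical value among the three; the other two stop at the limit of > 100000 nM in this assay, at which 2 of the 3 values shown sit. Compound 4, `Cc1ccc2[nH]c(=O)c(-c3nc4cc(F)ccc4[nH]3)cc2c1`, differs from compound 2 by methyl in place of hydrogen on an aromatic carbon, the methyl entering on an aromatic carbon of a six-membered aromatic ring of carbon only, part of a fused system of two rings, meta to a fused ring and para to a fused ring. Of the two measured steps, the one at the same carbon is an at least 3.6-fold lower number from compound 1 to compound 2 (0.56 log units; beyond the scatter). The other, an at least 3.6-fold higher number from compound 2 to compound 3 (0.56 log units; beyond the scatter), concerns a different carbon and bears less directly. Compound 1, carrying methoxy at this carbon, sits at the limit > 100000 nM. A methyl at the same place is expected to move the number upward again, with the step from compound 2 to compound 4 estimated at a 2.0-fold higher number from compound 2 to compound 4 (0.30 log units; within the scatter). Compound 4 is expected at 55000 nM, within a range from 20000 nM to 150000 nM, with a real chance that only a limit is reported.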

Compound 4, half-maximal inhibitory concentration: > 100000 nM
Compound 4 ended at the assay's limit (the forecaster's own chance of this, stated with the estimate: 40%); middle value at least 1.8-fold (0.25 log units) from the limit.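

In this assay, methyl in place of hydrogen at this carbon gives an at least 3.6-fold higher number from compound 2 to compound 4 (0.56 log units; beyond the scatter), so the loss of a readable number here no longer rests on methoxy alone, and a group with no hydrogen-bond acceptor and only one heavy atom is enough to produce it. Of the groups shown at this carbon, only hydrogen, in compound 2, leaves a number that can be read, while methyl and methoxy both end at a limit of the assay, so the step between those two cannot be read and nothing places one ahead of the other. The series now gathers at a single ceiling, which narrows what it can say about the groups that reach it: the limit of > 100000 nM in this assay, at which 3 of the 4 values shown sit.

On these data alone, it remains open whether any other group at this carbon, such as a hydroxyl, an amine or a carboxylic acid, would hold or improve on compound 2, at 27500 nM. As far as these compounds go, how far the true values of compound 1 and compound 4 lie past the limit also stays unknown, as does whether a methyl would have the same effect on a core carrying a group other than fluoro.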